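A few compounds are considered here, and "the series" means these few. Any claim that something is new, unique, unknown or untested is made for them only; others in the source may bear on it.

Series notes. In a functional assay on HEK293 cells for agonist activity at G-protein coupled receptor 39 (Homo sapiens), read by scintillation proximity assay and inositol phosphate accumulation, with a stated time of 75 min, in the presence of a further agent that is not named here (on this read-out higher numbers stand for an effect only at larger amounts of compound and lower numbers for an effect already at smaller amounts), compound 1 `Cc1nn(-c2ncnc3nc[nH]c23)c2c1C(C(=O)NCc1ccccc1)CC(=O)N2` gives 5 nM, the lowest of the three numbers at hand. Compound 2 `CC(C)(C)c1cc(C(=O)N/N=C/c2ccc(O)cc2O)[nH]n1` gives 240 nM in this assay, and compound 3 `C=CCN1c2c(n(C)c(=O)n(C)c2=O)NC1N/N=C/c1ccc(O)cc1O` gives 340 nM in this assay; both gaps to compound 1 lie beyond the scatter. Compound 4 `Cc1nn(-c2ncnc3nc[nH]c23)c2c1C(OCCn1cccn1)CC(=O)N2` has not yet been measured. It differs from compound 1 in one place: 2-(1H-pyrazol-1-yl)ethoxy in place of benzylcarbamoyl on a saturated ring carbon. Going by the values given here, no measured pair shows a change of this kind, so the data give no size for such a step. The change is expected to raise the number in this assay, with a step of an 8.0-fold higher number from compound 1 to compound 4 (0.90 log units; beyond the scatter) of moderate size, beyond the scatter. Compound 4 is therefore expected to give 40 nM in this assay, within a range from 5 nM to 300 nM.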

Compound 4, half-maximal effective concentration: 16 nM
Estimate against measurement, compound 4: 2.5-fold (0.40 log units) above; the range from low to high includes it.
By their numbers in this assay, from the lowest: compound 1; then compound 4; then compounds 2 and 3 (each within the scatter of the next).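

In this assay the saturated ring carbon tolerates a change of side chain: 2-(1H-pyrazol-1-yl)ethoxy in place of benzylcarbamoyl gives a 3.2-fold higher number from compound 1 to compound 4 (0.51 log units; beyond the scatter) and the step is modest. The carbon-only aromatic ring and the hydrogen-bond donor of benzylcarbamoyl are therefore not needed for compound 4 to reach 16 nM in this series, though compound 1 keeps the lower number. Nothing at hand explains the size of this step.

Open, going by these compounds, is how a carboxylic acid or a primary amine at this carbon would compare, and whether a phenyl ring in place of the pyrazole on the ethoxy chain would move the number.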